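Nitro in place of methyl on the anilino ring

The compounds below may be only part of what the source reports. "The series", "measured", "known", "first", "only" and "open" are said of these compounds alone.

Compound 2 `Cc1ccc(Nc2nccc(-c3nn(C)c4ccccc34)n2)cc1` gives 6100 nM in a functional assay on MCF7 cells (Homo sapiens) for antiproliferative activity, read by MTT assay, with a stated time of 72 h (a lower number here means a stronger inhibitor of growth, a higher number a weaker inhibitor of growth), the lowest of the three numbers, though compound 3 `Cc1cccc(Nc2nccc(-c3nn(C)c4ccccc34)n2)c1` at 9150 nM lies within the scatter of it, with a 1.5-fold higher number from compound 2 to compound 3 (0.18 log units; within the scatter). Compound 1 `Cn1nc(-c2ccnc(Nc3cccc(O)c3)n2)c2ccccc21` gives 28200 nM. Compound 4 `Cn1nc(-c2ccnc(Nc3ccc([N+](=O)[O-])cc3)n2)c2ccccc21` differs from compound 2 by nitro in place of methyl on an aromatic carbon, on an aromatic carbon of a six-membered aromatic ring of carbon only, para to a large group. Among the compounds with values here, the only step that changes this ring's substituent beyond the scatter is a 4.6-fold lower number from compound 1 to compound 2 (0.66 log units; beyond the scatter); no measured step involves a nitro group, so the direction is uncertain. Compound 4 is therefore expected to stay near compound 2, with a 1.3-fold higher number from compound 2 to compound 4 (0.12 log units; within the scatter), and its estimated value is 8000 nM (range 2500 nM to 25000 nM).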

Compound 4, concentration for 50% growth inhibition: 11800 nM
Estimate against measurement, compound 4: 1.5-fold (0.17 log units) below, within the range that was stated.
By their numbers in this assay, from the lowest: compounds 2, 3 and 4 (each within the scatter of the next); then compound 1.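

Within the data shown here, the first nitro group gives a 1.9-fold higher number from compound 2 to compound 4 (0.29 log units; within the scatter) in this assay, so exchanging methyl for nitro on this aromatic carbon, para to a large group, produces no change that can be told from the scatter. This carbon therefore accepts a substituent of three heavy atoms with two hydrogen-bond acceptors in place of a single carbon, with the number staying within the scatter. Nothing measured on these compounds offers an explanation for this result. On these data alone, whether an amine or a carboxylic acid on this same carbon would move the number beyond the scatter remains open.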